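Isoxazole regioisomer swap in a urea solubility series

The source may hold more compounds than are shown below. What is called first, only, known or untested is meant among the compounds shown, and "the series" means these compounds.

Working notes on the series. Compound 1 `CCCCc1ccc(NC(=O)N2CCCN(C(=O)CCC3CCCC3)CC2)cc1` gives 3 ug/mL in a physicochemical assay for solubility, at pH 7.4; a higher number here means a more soluble compound, a lower number a less soluble compound. Compound 2 `CC(C)(C)c1cc(NC(=O)N2CCCN(C(=O)C3CCOCC3)CC2)no1` is reported in this assay only as a limit, > 37 ug/mL, not as a number. That limit is the limit of > 37 ug/mL in this assay, at which 1 of the 2 values shown sits. Compound 3 `CC(C)(C)c1cc(NC(=O)N2CCCN(C(=O)C3CCOCC3)CC2)on1` has not yet been measured in this assay; it differs from compound 2 by 3-(tert-butyl)-1,2-oxazol-5-yl in place of 5-(tert-butyl)-1,2-oxazol-3-yl on an amide-type nitrogen, the two having the same atoms joined differently. Among the compounds with values here, no measured step connects compound 2 and compound 3 in this assay, and compound 1 is not linked to either by a single change. The expected step that the limit leaves unreadable from compound 2 to compound 3 is none beyond the scatter, in either direction. Compound 3 is therefore estimated at 40 ug/mL in this assay, with a range from 15 ug/mL to 110 ug/mL, and most likely it too is expected to be reported only as a limit.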

Compound 3, solubility: > 37 ug/mL
Compound 3: only a limit was reported; the forecaster's own chance of this, stated with the estimate: 65%; the middle value does not contradict the limit.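

Within the data shown here, compound 2 and compound 3 are both reported only as limits, so no step between them can be read in this assay: the limit of > 37 ug/mL in this assay, at which 2 of the 3 values shown sit. The compounds shown leave open whether in this assay the 3-(tert-butyl)-1,2-oxazol-5-yl group differs at all from the 5-(tert-butyl)-1,2-oxazol-3-yl group.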